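This account rests on a few compounds, and the source may have more. Where it says the series, first, only, none or still open, it means among the compounds named here.

Measured so far:
Compound 1 `Cc1cnc(NCC2(c3ccc(F)cc3)CC2)c(=O)n1CC(=O)NCc1ccc2[nH]nc(N)c2c1`: 2.07 h
Compound 2 `Cc1cnc(NCC2(c3ccc(F)cc3)CC2)c(=O)n1CC(=O)NCc1ccc2c(N)noc2c1`: 2.17 h

Among the measured compounds shown here, in an in vivo ADME assay on the whole organism with Canis familiaris (Canis lupus familiaris) as the target (on this read-out lower numbers stand for a shorter-lived compound and higher numbers for a longer-lived compound), compound 1 gives 2.07 h, and its only neighbour is compound 2, where the change in the group on the saturated chain carbon bound to the amide-type nitrogen brought a 1.0-fold higher number from compound 1 to compound 2 (0.02 log units; within the scatter). Compound 1 and compound 2 therefore sit within the scatter of each other.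

Compound 3 `COc1ccc(C2(CNc3ncc(C)n(CC(=O)NCc4ccc5[nH]nc(N)c5c4)c3=O)CC2)cc1` carries methoxy in place of fluoro on an aromatic carbon. For the measured compounds named here, no measured step touches this ring position, since the one step known lies elsewhere in the molecule, so nothing in the data points in either direction. Compound 3 is therefore estimated near compound 1, at 1.8 h with a range of 0.8 h to 4 h. The step expected in this assay is a 1.2-fold lower number from compound 1 to compound 3 (0.06 log units; within the scatter), and the estimate is given a wide range for want of a comparable step.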

Compound 3, half-life in the Canis familiaris assay: 1.48 h
Beside the measured number, compound 3's estimate is 1.2-fold (0.09 log units) above it; the range from low to high includes it.
By their numbers in the Canis familiaris assay, from the lowest: compounds 3, 1 and 2 (each within the scatter of the next).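

Among the compounds shown here, in the Canis familiaris assay the change from 4-fluorophenyl to 4-methoxyphenyl gives a 1.4-fold lower number from compound 1 to compound 3 (0.15 log units; within the scatter) and thus shows that this position, untouched by the earlier compounds, can carry either group without a step beyond the scatter. In a physicochemical assay for acid dissociation, the same change gives no change at the digits printed from compound 1 to compound 3 (within the scatter) with compound 1 at 3.6 and compound 3 at 3.6 on that read-out. Nothing measured here accounts for either result.

On these data alone, whether an amine or a carboxylic acid on this aromatic carbon would also stay within the scatter remains open, as does the effect of methoxy in place of fluoro on compound 2.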